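The source may report more compounds than this note shows. Statements on the series, on what has been measured and on what is new or still open speak of the compounds shown alone.

Working notes on the series.

Of the compounds shown here, three sharing one core have been measured in a functional assay on MDA-MB-231 cells (Homo sapiens) for inhibition, read by MTT assay, with a stated time of 72 h; a higher number here means a weaker inhibitor, a lower number a stronger inhibitor. Compound 1 `O=C(CSc1nc(Nc2ccccc2)c2ccccc2n1)Nc1cccc(Cl)c1` gives 16500 nM. Compound 2 `O=C(CSc1nc(Nc2ccccc2)c2ccccc2n1)Nc1ccc(F)cc1` gives 34100 nM, and compound 3 `CCc1ccc(NC(=O)CSc2nc(Nc3ccccc3)c3ccccc3n2)cc1` gives 33900 nM. Compound 3 therefore stands second highest of the three numbers, with compound 2 within the scatter of it and compound 1 lying furthest off, the step being a 2.1-fold higher number from compound 1 to compound 3 (0.31 log units; beyond the scatter).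

Compound 4 `O=C(CSc1nc(Nc2ccccc2)c2ccccc2n1)Nc1ccc(F)c(Cl)c1` has not yet been measured. It differs from compound 3 by 3-chloro-4-fluorophenyl in place of 4-ethylphenyl on an amide-type nitrogen. Within the data shown here, two measured steps bear on this change: a 2.1-fold higher number from compound 1 to compound 3 (0.31 log units; beyond the scatter) and a 2.1-fold higher number from compound 1 to compound 2 (0.32 log units; beyond the scatter), both of which run from the 3-chlorophenyl compound 1 to a 4-substituted phenyl. Compound 4 carries the 3-chloro of compound 1 together with the 4-fluoro of compound 2, so the expected step of a 1.9-fold lower number from compound 3 to compound 4 (0.27 log units; within the scatter) is a modest move back toward compound 1, a lower number in this assay, given that compound 1 sits at 16500 nM. For compound 4 the estimate is 18000 nM, with a range from 8000 nM to 40000 nM.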

Compound 4, half-maximal inhibitory concentration: 21600 nM
The estimate for compound 4 lay 1.2-fold (0.08 log units) below the measured number, within the range that was stated.
By their numbers in this assay, from the lowest: compounds 1, 4, 3 and 2 (each within the scatter of the next, the first and the last beyond it).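

In this assay fluoro in place of hydrogen on an aromatic carbon gives a 1.3-fold higher number from compound 1 to compound 4 (0.12 log units; within the scatter) and chloro in place of hydrogen on an aromatic carbon gives a 1.6-fold lower number from compound 2 to compound 4 (0.20 log units; within the scatter) so neither single change to the phenyl on the amide-type nitrogen leaves the scatter. With 3-chloro-4-fluorophenyl in place of 4-ethylphenyl giving a 1.6-fold lower number from compound 3 to compound 4 (0.20 log units; within the scatter) as well, compound 4 sits within the scatter of compound 1, compound 2 and compound 3, although compound 1 lies beyond the scatter of the other two. No evidence at hand accounts for these steps.

The compounds shown leave open whether a methoxy, an amine or a carboxylic acid on this phenyl would give a step beyond the scatter. They also leave open what a cyclohexyl in place of the phenyl would do.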